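This account rests on a few compounds, and the source may have more. Where it says the series, first, only, none or still open, it means among the compounds named here.

Working notes on the stilbene-type series of hydroxylated compounds, all tested in a functional assay on HT-29 cells (Homo sapiens) for inhibition, read by MTT assay, with a stated time of 2 days; a higher number here means a weaker inhibitor, a lower number a stronger inhibitor.

Compound 1 `Oc1ccccc1/C=C/c1ccccc1O` gives 25 ug/mL in this assay. Compound 2 `Oc1cccc(/C=C/c2ccccc2O)c1` gives 27 ug/mL in this assay. Compound 3 `Oc1ccc(/C=C/c2ccccc2O)cc1` gives 22 ug/mL in this assay. Compound 2 stands together with compound 1 and compound 3: none of the three numbers separates from another beyond the scatter, so the three read as one level rather than a ranking.

Compound 4 `Nc1ccccc1/C=C/c1cccc(O)c1` has not been measured in this assay. It differs from compound 2 by amino in place of hydroxy on an aromatic carbon. For the measured compounds named here, no pair of measured compounds shows this swap, so there is no measured step to lean on; the three measured numbers only show that moving the second hydroxy around the ring leaves the read-out unchanged within the scatter.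

Going by the values given here, with no measured precedent for the amino-for-hydroxy exchange, the step from compound 2 to compound 4 is expected to be small, no change at the digits printed from compound 2 to compound 4 (within the scatter), with no direction favoured beyond the scatter. Compound 4 is accordingly estimated at 27 ug/mL in this assay, within a range of 12 ug/mL to 60 ug/mL.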

Compound 4, half-maximal inhibitory concentration: 30 ug/mL
Estimate against measurement, compound 4: 1.1-fold (0.05 log units) below; measured number inside the range.
By their numbers in this assay, from the lowest: compounds 3, 1, 2 and 4 (each within the scatter of the next).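

In this assay amino in place of hydroxy on an aromatic carbon, ortho to a group of 9 heavy atoms, gives a 1.1-fold higher number from compound 2 to compound 4 (0.05 log units; within the scatter) and so does not separate the two compounds. For the compounds shown here, compounds 1, 2 and 3 all keep the hydroxy on this carbon, so this is the first change at this place, and here hydroxy can give way to amino with the read-out held at the level of compound 2. Nothing available bears on why the read-out holds across this exchange.

One exchange at one place says little about how far this carbon tolerates change, and a methoxy, a carboxylic acid or a longer chain here could read differently. On these data alone, whether amino behaves the same way with the other hydroxy elsewhere on its ring also stays open.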